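The source may hold more compounds than are shown below. What is called first, only, known or untested is meant among the compounds shown, and "the series" means these compounds.

Working notes on the series. Compound 1 `CC(=O)NS(=O)(=O)c1ccc(N/C(S)=N\c2ccnc3cc(C(F)(F)F)ccc23)cc1`, compound 2 `Cc1cc(NS(=O)(=O)c2ccc(N/C(S)=N\c3ccnc4cc(C(F)(F)F)ccc34)cc2)on1` and compound 3 `O=S(=O)(Nc1nccs1)c1ccc(N/C(S)=N\c2ccnc3cc(C(F)(F)F)ccc23)cc1` share one core and differ only in the group carried on the sulfonamide nitrogen. In a functional assay on HeLa cells (Homo sapiens) for antiproliferative activity, read by sulforhodamine B assay, with a stated time of 48 h (on this read-out lower numbers stand for stronger inhibition and higher numbers for weaker inhibition), compound 1 gives 37600 nM, compound 2 gives 60200 nM and compound 3 gives 95200 nM. Compound 3 carries the highest number of the three: the step of a 2.5-fold higher number from compound 1 to compound 3 (0.40 log units; beyond the scatter) lies beyond the scatter, whereas the step of a 1.6-fold higher number from compound 2 to compound 3 (0.20 log units; within the scatter) does not, and the step of a 1.6-fold higher number from compound 1 to compound 2 (0.20 log units; within the scatter) does not either. Compound 4 `O=S(=O)(Nc1ncccn1)c1ccc(N/C(S)=N\c2ccnc3cc(C(F)(F)F)ccc23)cc1` is the next member; its change from compound 3 is pyrimidin-2-yl in place of 1,3-thiazol-2-yl on a sulfonamide nitrogen. Among the measured compounds shown here, the steps that bear on this are the two that put a ring on that nitrogen in place of another group: only the step from acetyl reached beyond the scatter, and the ring-for-ring exchange stayed within it. A further ring-for-ring exchange on compound 3 is therefore expected to move this assay little, with no direction beyond the scatter, and the estimated step is a 1.2-fold lower number from compound 3 to compound 4 (0.08 log units; within the scatter). Compound 4 is estimated at 80000 nM, with a range from 30000 nM to 200000 nM.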

Compound 4, half-maximal inhibitory concentration: "not active" (no number reported)
Compound 4 has no reported number here, so the estimate cannot be set against anything.
By their numbers in this assay, from the lowest: compounds 1, 2 and 3 (each within the scatter of the next, the first and the last beyond it).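

Among the compounds shown here, compound 4 is reported as "not active" in this assay with no number, so no step from compound 1, compound 2 or compound 3 to compound 4 can be read. No measured evidence bears on this result. The compounds shown leave open how far compound 4 stands from compound 3 on this read-out.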